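Notes on the sulfur-linked heteroaryl of the series

The compounds below may be only part of what the source reports. "The series", "measured", "known", "first", "only" and "open" are said of these compounds alone.

Of the compounds shown here, two carry a number so far. Compound 1 `CC(C)[C@H](NC(=O)COc1cccc2ccccc12)C(=O)N[C@@H](CC(=O)O)C(=O)CSc1nnc(-c2ccccc2)o1` gives 150000 nM in a functional assay on Jurkat cells (Homo sapiens) for inhibition; a lower number here means a stronger inhibitor, a higher number a weaker inhibitor. Compound 2 `Cc1nnc(SCC(=O)[C@H](CC(=O)O)NC(=O)[C@@H](NC(=O)COc2cccc3ccccc23)C(C)C)s1` gives 190000 nM in this assay, the highest of the two numbers; its nearest neighbour is compound 1, and the step of a 1.3-fold higher number from compound 1 to compound 2 (0.10 log units; within the scatter) lies within the scatter, so no order between them can be claimed. Compound 3 `CC(C)[C@H](NC(=O)COc1cccc2ccccc12)C(=O)N[C@@H](CC(=O)O)C(=O)CSc1nc2ccccc2[nH]1` has not been measured; it differs from compound 2 in one place: 1H-benzimidazol-2-yl in place of 5-methyl-1,3,4-thiadiazol-2-yl on a sulfur. Within the data shown here, the only measured step that bears on this change is the earlier exchange of the heteroaryl on the same sulfur, a 1.3-fold higher number from compound 1 to compound 2 (0.10 log units; within the scatter), which did not move the number beyond the scatter. A second exchange at that place is expected to behave alike, with no step beyond the scatter in either direction: no change at the digits printed from compound 2 to compound 3 (within the scatter). Compound 3 is accordingly estimated at 190000 nM in this assay, with a range from 60000 nM to 600000 nM.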

Compound 3, half-maximal inhibitory concentration: > 200000 nM
Compound 3: only a limit was reported; the forecaster's own chance of this, stated with the estimate: 25%; middle value at least 1.0-fold (0.02 log units) from the limit.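

For compound 3, this assay gives only a limit, > 200000 nM, and not a number. Read as floors, the steps are an at least 1.0-fold higher number from compound 2 to compound 3 (0.02 log units; that floor lies within the scatter) and an at least 1.3-fold higher number from compound 1 to compound 3 (0.12 log units; that floor lies within the scatter), so neither establishes a real gap, though a larger one stays possible. The 1H-benzimidazol-2-yl, the only group shown on this sulfur with a hydrogen-bond donor, brings no stronger inhibition, and one reading of the three heteroaryl exchanges now sits at the end of the measured range: the limit of > 200000 nM in this assay, at which 1 of the 3 values shown sits.

From the compounds shown here alone, how far compound 3 lies past its limit remains open, and so does any order among the three compounds. Also open, going by these compounds, is whether an amine or a longer chain in place of the heteroaryl on the sulfur would move the number beyond the scatter.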